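Compound 3 and a move to methyl groups only

This account rests on a few compounds, and the source may have more. Where it says the series, first, only, none or still open, it means among the compounds named here.

- compound 1 `CCC1=C(O)c2c(oc(-c3ccc(C)cc3)cc2=O)C(CC)(CC)C1=O`: 0.08 uM
- compound 2 `CCC1=C(O)c2c(oc(-c3ccc(O)cc3)cc2=O)C(CC)(CC)C1=O`: 20.6 uM
- compound 3 `CCC1=C(O)c2c(oc(-c3ccc(OC)cc3C)cc2=O)C(CC)(CC)C1=O`: 2.62 uM

These three compounds share one core and differ only in the aromatic group attached to it. All were tested in a functional assay on KBVIN cells (Homo sapiens) for antiproliferative activity, read by sulforhodamine B assay, with a stated time of 3 days; a higher number here means that more compound is needed for the effect, a lower number that less compound is needed. Compound 3, at 2.62 uM, falls in the middle of the three. The data show a 7.9-fold lower number from compound 2 to compound 3 (0.90 log units; beyond the scatter). On the other side they show a 33-fold higher number from compound 1 to compound 3 (1.52 log units; beyond the scatter).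

The next compound, compound 4 `CCC1=C(O)c2c(oc(-c3cccc(C)c3C)cc2=O)C(CC)(CC)C1=O`, alters that same group, with 2,3-dimethylphenyl in place of 4-methoxy-2-methylphenyl on an aromatic carbon.

Within the data shown here, no measured compound carries this exact group, so the evidence is indirect. Compound 1, at 0.08 uM, is the closest match, since its aromatic group also bears only methyl. Among the measured compounds shown here, the two large steps away from it, a 260-fold higher number from compound 1 to compound 2 (2.41 log units; beyond the scatter) and the one to compound 3 above, suggest that this group strongly affects the number. A move toward compound 1 is therefore expected, but probably not all the way. The expected change is a 4.4-fold lower number from compound 3 to compound 4 (0.64 log units; beyond the scatter). The estimated value for compound 4 is 0.6 uM, with an expected range of 0.12 uM to 3 uM.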

Compound 4, concentration for half-maximal effect: 0.85 uM
Compound 4: middle estimate off by 1.4-fold (0.15 log units), on the low side; measured number inside the range.
By their numbers in this assay, from the lowest: compound 1; then compound 4; then compound 3; then compound 2.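

Within this set, the group on this aromatic carbon can lose its oxygen and keep only methyl groups: 2,3-dimethylphenyl gives a 3.1-fold lower number from compound 3 to compound 4 (0.49 log units; beyond the scatter) in this assay, and against the 4-hydroxyphenyl group the change is larger, a 24-fold lower number from compound 2 to compound 4 (1.38 log units; beyond the scatter). Among these compounds, the two groups carrying only methyl now have the lowest numbers and the two carrying oxygen the highest, with no compound among the four going against this, yet having only methyl groups does not settle the value, as there is still an 11-fold higher number from compound 1 to compound 4 (1.03 log units; beyond the scatter). Nothing measured here explains why these aromatic groups differ so much.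

The 2,3-dimethylphenyl and 4-methylphenyl groups differ in both how many methyl groups they carry and where these sit, so the compounds shown cannot say which of the two matters for the higher number of compound 4. They also leave open how a longer chain, as in 4-ethylphenyl, or an amine or a chlorine on the same aromatic ring would compare with the methyl groups.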